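Compound 2 to compound 3: phenyl replaces 3,4-dimethoxyphenyl

The source may report more compounds than this note shows. Statements on the series, on what has been measured and on what is new or still open speak of the compounds shown alone.

Compound 1 `COC(=O)c1cc(C2=C(c3cc(OC)c(OC)c(OC)c3)C(=O)CC2O[SiH2]C(C)(C)C)ccc1OC`: > 100 ug/mL
Compound 2 `COc1ccc(C2=C(c3cc(OC)c(OC)c(OC)c3)C(=O)CC2O[SiH2]C(C)(C)C)cc1OC`: > 100 ug/mL

In an ADME assay on PA-1 cells (Homo sapiens) for cytotoxicity, read by MTT assay, with a stated time of 72 h (a higher number here means a weaker inhibitor, a lower number a stronger inhibitor), compound 2 gives > 100 ug/mL, which is a limit of the assay and not a number. Compound 1 gives > 100 ug/mL, likewise a limit. Together these make up (the limit of > 100 ug/mL in this assay, at which 2 of the 2 values shown sit).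

Compound 3 `COc1cc(C2=C(c3ccccc3)C(O[SiH2]C(C)(C)C)CC2=O)cc(OC)c1OC` differs from compound 2 in one place, with phenyl in place of 3,4-dimethoxyphenyl on a double-bonded ring carbon.

Within the data shown here, the only measured step, a step that the two limits leave unreadable from compound 1 to compound 2, is a different change and gives no size to carry over. No step beyond the scatter can therefore be expected in this assay, and no direction can be given. Compound 3 is expected to stay near the limit, and quite possibly to be reported only as a limit. The expected step is a number no higher from compound 2 to compound 3 (the limit leaves the size open). The estimate for compound 3 is 100 ug/mL, within an expected range from 50 ug/mL to 200 ug/mL.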

Compound 3, half-maximal inhibitory concentration: > 100 ug/mL
Compound 3: a limit, no number; the forecaster's own chance of this, stated with the estimate: 75%; the middle value sits exactly at the limit.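

No new step can be read among compound 1, compound 2 and compound 3 in this assay, because each gives only a limit and not a number: the limit of > 100 ug/mL in this assay, at which 3 of the 3 values shown sit.

These compounds leave open how strong each one actually is, and whether phenyl in place of 3,4-dimethoxyphenyl changes the read-out at all.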